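The compounds below may be only part of what the source reports. "The series", "measured", "known", "first", "only" and "open" are said of these compounds alone.

Working notes on a short urea series. Compound 1 `Cc1ccc(NC(=O)N[C@@H](C)c2ccccc2)cc1` gives 99% in an ADME assay on the whole organism with Oryza sativa as the target, tested at 1 uM; a lower number here means a stronger effect, a higher number a weaker effect of the compound at the concentration tested. Compound 2 `CCc1ccc(NC(=O)N[C@@H](C)c2ccccc2)cc1` gives 95% in this assay, and compound 3 `C[C@H](NC(=O)Nc1ccc(C(C)(C)C)cc1)c1ccccc1` gives 88% in this assay. Compound 3 stands lowest of the three numbers shown: the gap a number 7 percentage points lower from compound 2 to compound 3 (within the scatter) is within the scatter, while the gap a number 11 percentage points lower from compound 1 to compound 3 (beyond the scatter) is beyond it, so compound 3 is separated from compound 1 but not from compound 2. The remaining measured step, a number 4 percentage points lower from compound 1 to compound 2 (within the scatter), is also within the scatter.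

Compound 4 `CCCCc1ccc(NC(=O)N[C@@H](C)c2ccccc2)cc1` is not yet measured. It differs from compound 3 in that (butyl in place of tert-butyl on an aromatic carbon). Within the data shown here, no measured step in this set exchanges one four-carbon group for another of the same atom count, so the nearest guides are the steps onto the tert-butyl compound, a number 11 percentage points lower from compound 1 to compound 3 (beyond the scatter) and a number 7 percentage points lower from compound 2 to compound 3 (within the scatter), one modest and one within the scatter. A step of no more than the scatter is therefore expected in this assay, in either direction. For compound 4 the estimated value in this assay is 86%, with a range from 72% to 97%, which amounts to an expected step of a number 2 percentage points lower from compound 3 to compound 4 (within the scatter).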

Compound 4, a percentage reported as activity, at one concentration (the size of the read-out at that concentration, not a potency): 72%
Compound 4: middle estimate off by 14 percentage points, on the high side; the range from low to high includes it.
By their numbers in this assay, from the lowest: compound 4; then compounds 3, 2 and 1 (each within the scatter of the next, the first and the last beyond it).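

With the same four carbons present, butyl in place of tert-butyl on an aromatic carbon gives a number 16 percentage points lower from compound 3 to compound 4 (beyond the scatter) in this assay, so at this position the way the carbons are joined matters to the read-out, not only their number. Among these compounds, the butyl compound also separates clearly from the two compounds with shorter groups, with a number 23 percentage points lower from compound 2 to compound 4 (beyond the scatter) and a number 27 percentage points lower from compound 1 to compound 4 (beyond the scatter), and compound 4 is the only compound here with all of its steps to the others beyond the scatter. Nothing available bears on why the butyl group behaves differently from the tert-butyl group.

Still open, on these data alone, is whether a longer chain such as hexyl would take the number lower still or reverse the step. Also open, as far as these compounds go, is whether a propyl group, or a butyl chain ending in an amine or a carboxylic acid, would keep the step.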